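A Methoxymethoxy Group Added at the Assay Limit

A few compounds are considered here, and "the series" means these few. Any claim that something is new, unique, unknown or untested is made for them only; others in the source may bear on it.

In an ADME assay on HEp-2 cells (Homo sapiens) for cytotoxicity, read by MTT assay, with a stated time of 72 h (on this read-out lower numbers stand for stronger inhibition and higher numbers for weaker inhibition), compound 1 `COc1ccc(C2=C(c3cc(OC)c(OC)c(OC)c3)C(=O)CC2O[SiH2]C(C)(C)C)cc1` gives > 100 ug/mL, which is a limit of the assay and not a number. Compound 2 `COc1ccc(C2=C(c3cc(OC)c(OC)c(OC)c3)C(=O)CC2O)cc1` gives > 100 ug/mL, which is also a limit. Going by the values given here, the only measured step is therefore a step that the two limits leave unreadable from compound 1 to compound 2, and the data so far amount to the limit of > 100 ug/mL in this assay, at which 2 of the 2 values shown sit.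

Compound 3 `COCOc1cc(C2=C(c3cc(OC)c(OC)c(OC)c3)C(=O)CC2O[SiH2]C(C)(C)C)ccc1OC` keeps the core of compound 1 and changes one place: methoxymethoxy in place of hydrogen on an aromatic carbon. The measured step concerns an oxygen on a saturated carbon, a different place, and has no readable size. It therefore gives no direction for this change, and no step beyond the scatter in this assay is expected. The expected size is a number no higher from compound 1 to compound 3 (the limit leaves the size open). For compound 3 the estimated value is 100 ug/mL, with an expected range from 50 ug/mL to 200 ug/mL.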

Compound 3, half-maximal inhibitory concentration: 12 ug/mL
Beside the measured number, compound 3's estimate is 8.3-fold (0.92 log units) above it; measured number below the stated range.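

In this assay, methoxymethoxy in place of hydrogen on the aromatic carbon ortho to a methoxy group gives an at least 8.3-fold lower number from compound 1 to compound 3 (0.92 log units; beyond the scatter), and a lower number here means stronger inhibition. This place on the 4-methoxyphenyl ring therefore responds to a change, whereas the step at the oxygen on a saturated carbon cannot be read. Compound 3 is also the only compound shown with a true number rather than a limit, so it gives later changes a value to be compared against: the limit of > 100 ug/mL in this assay, at which 2 of the 3 values shown sit.

The compounds shown leave open whether this effect belongs to methoxymethoxy itself or would also appear with a hydroxyl group, an amine or a longer chain at the same place. They also leave open whether the same change would lower the number for compound 2.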